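Swapping a Nitro Group for Fluorine at the Ring Edge

The source may report more compounds than this note shows. Statements on the series, on what has been measured and on what is new or still open speak of the compounds shown alone.

Compound 1 `O=C(NCc1ccc(CNS(=O)(=O)c2ccc([N+](=O)[O-])cc2)cc1)c1cccnc1` was tested in an assay on MDA-MB-231 cells for displacement of a labelled ligand from C-X-C chemokine receptor type 4 (Homo sapiens), read by fluorescence and microscopy, with stated times of 10 min and 30 min (on this read-out lower numbers stand for an effect already at smaller amounts and higher numbers for an effect only at larger amounts of compound), and gives 100 nM. For the measured compounds named here, only one other compound has a number here: compound 2 `Cc1cccc(S(=O)(=O)NCc2ccc(CNC(=O)c3ccccc3C)cc2)c1` gives 1000 nM in this assay, a higher value whose gap to compound 1 lies beyond the scatter. Going by the values given here, compound 1 therefore holds the lowest value of the two measured compounds, though the pair share little beyond the central linker, so no single structural step connects them.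

Compound 3 `O=C(NCc1ccc(CNS(=O)(=O)c2ccc(F)cc2)cc1)c1cccnc1` is the one not yet measured. It differs from compound 1 in a single spot: fluoro in place of nitro on an aromatic carbon. The exchange removes the group counted above and leaves a far smaller one in its place, with no ring and no hydrogen-bond acceptors entering.

Among the compounds with values here, with no measured step of this kind available, a modest rise in this assay is expected for compound 3, with a 2.5-fold higher number from compound 1 to compound 3 (0.40 log units; beyond the scatter) as the anticipated step. Compound 3 is estimated at 250 nM, within a range of 80 nM to 800 nM.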

Compound 3, effective concentration (reported as EC, without a stated level of effect): 100 nM
For compound 3 the middle estimate is 2.5-fold (0.40 log units) above the measured one, and the stated range covers the measured number.
By their numbers in this assay, from the lowest: compounds 1 and 3 (each within the scatter of the next); then compound 2.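

In this assay, for the compounds shown here, replacing nitro with fluoro on this aromatic carbon, para to a large group, gives no change at the digits printed from compound 1 to compound 3 (within the scatter), the first direct reading of a change at this place. The 4-nitrophenyl group can therefore give way to 4-fluorophenyl, a much smaller group without the hydrogen-bond acceptors of nitro, with no difference beyond the scatter in this read-out. No measured information is available to explain why these two groups read alike.

The compounds shown leave open how other groups at this place would read, such as an amine, a carboxylic acid or a methoxy group. They also leave open whether fluoro and nitro would still read alike if the rest of the core of compound 1 were changed.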